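Compound 4: another 4-methylpiperazin-1-yl variant of compound 1

The source may hold more compounds than are shown below. What is called first, only, known or untested is meant among the compounds shown, and "the series" means these compounds.

- compound 1 `O=C(/C=C/c1cccc(/C=C/C(=O)c2ccccc2)c1)NO`: 3210 nM
- compound 2 `CN1CCN(c2ccccc2C(=O)/C=C/c2cccc(/C=C/C(=O)NO)c2)CC1`: 1290 nM
- compound 3 `CN1CCN(c2cccc(C(=O)/C=C/c3cccc(/C=C/C(=O)NO)c3)c2)CC1`: 990 nM

In a functional assay on K562 cells (Homo sapiens) for antiproliferative activity, read by MTT assay, with a stated time of 72 h (on this read-out lower numbers stand for stronger inhibition and higher numbers for weaker inhibition), compound 1 has the highest number of the three, 3210 nM, which makes it the weakest inhibitor measured so far. Compound 4 `CN1CCN(c2ccc(C(=O)/C=C/c3cccc(/C=C/C(=O)NO)c3)cc2)CC1` is still unmeasured and differs from it in one place: 4-methylpiperazin-1-yl in place of hydrogen on an aromatic carbon. It carries 4-methylpiperazin-1-yl in place of hydrogen on an aromatic carbon, para to a large group. Two measured steps make the same exchange elsewhere on the molecule: a 2.5-fold lower number from compound 1 to compound 2 (0.40 log units; beyond the scatter) and a 3.2-fold lower number from compound 1 to compound 3 (0.51 log units; beyond the scatter). Both are modest, beyond the scatter, and point the same way. A step of similar size and direction is therefore expected in this assay, a 2.9-fold lower number from compound 1 to compound 4 (0.47 log units; beyond the scatter). Compound 4 is estimated at 1100 nM, with an expected range of 500 nM to 2400 nM.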

Compound 4, half-maximal inhibitory concentration: 1170 nM
The estimate for compound 4 lay 1.1-fold (0.03 log units) below the measured number; the measured number falls inside the stated range.
By their numbers in this assay, from the lowest: compounds 3, 4 and 2 (each within the scatter of the next); then compound 1.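

Placed para to a large group, 4-methylpiperazin-1-yl again lowers the number in this assay with a 2.7-fold lower number from compound 1 to compound 4 (0.44 log units; beyond the scatter) and this modest step matches the other two in direction. Compounds 2, 3 and 4 lie within the scatter of one another, so among these three placements the choice of ring carbon makes no clear difference. From the compounds shown here alone, it remains open whether a morpholine ring or a simple dimethylamino group at the same place would give a similar step. Nothing shown gives a reason for the step.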